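This account rests on a few compounds, and the source may have more. Where it says the series, first, only, none or still open, it means among the compounds named here.

Measured so far in a physicochemical assay for solubility, in phosphate buffer, at 37 degrees C; on this read-out lower numbers stand for lower solubility and higher numbers for higher solubility:
- Compound 1 `CN(c1cccc(C(=O)O)c1)c1cc(O/N=[N+](\[O-])N(C)C)c([N+](=O)[O-])cc1[N+](=O)[O-]`: 3000000 nM
- Compound 2 `CN(C)/[N+]([O-])=N/Oc1cc(Nc2ccc(C(=O)O)cc2)c([N+](=O)[O-])cc1[N+](=O)[O-]`: > 3000000 nM (a limit of the assay, not a number)

Compound 2 has no exact number on this read-out, and it stands at the limit of > 3000000 nM in this assay, at which 1 of the 2 values shown sits. Among the compounds with values here, compound 1, the only compound with an exact reading, gives 3000000 nM in this assay.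

Compound 3 `CN(C)/[N+]([O-])=N/Oc1cc(Nc2cccc(C(=O)O)c2)c([N+](=O)[O-])cc1[N+](=O)[O-]` has not yet been measured. It carries 3-carboxyphenyl in place of 4-carboxyphenyl on a nitrogen on an aromatic ring. The two compounds have the same atoms, joined differently.

Within the data shown here, no measured pair shows a change of this kind, so the expectation has little to rest on. It leans on the reading of compound 1 at 3000000 nM. It also leans on compound 2, which gives > 3000000 nM, a limit of the assay. The expected step of a number no higher from compound 2 to compound 3 (the limit leaves the size open) is none beyond the usual scatter, with neither direction favoured. In this assay, compound 3 is estimated at 3000000 nM, with an expected range from 1200000 nM to 6000000 nM.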

Compound 3, solubility: > 2000000 nM
Compound 3: only a limit was reported; the forecaster's own chance of this, stated with the estimate: 50%; the middle value is on the limit's open side.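

In this assay compound 3 gives > 2000000 nM, a limit of the assay and not a number, so no step can be read from compound 1 or compound 2 to compound 3. The compounds shown leave open whether 3-carboxyphenyl in place of 4-carboxyphenyl, or hydrogen in place of methyl, on that nitrogen changes the read-out at all.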